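Removing One Fluoro Group from Compound 2

This account rests on a few compounds, and the source may have more. Where it says the series, first, only, none or still open, it means among the compounds named here.

- Compound 1 `Cc1noc(C)c1[C@@H]1C[C@@](C)(c2cc(NC(=O)c3ccc(Cl)cn3)c(F)cc2F)N=C(N)S1` gives 75%
- Compound 2 `Cc1noc(C)c1[C@@H]1C[C@@](C)(c2cc(NC(=O)c3ccc(Cl)cn3)cc(F)c2F)N=C(N)S1` gives 58%

In an ADME assay on liver (Mus musculus) for metabolic stability, using microsomes, with a stated time of 10 min, tested at 0.5 uM (on this read-out lower numbers stand for a less stable compound and higher numbers for a more stable compound), compound 2 stands lowest of the two measured compounds (at 58%), while compound 1 lies higher by a gap beyond the usual scatter. Compound 3 `Cc1noc(C)c1[C@@H]1C[C@@](C)(c2cc(F)cc(NC(=O)c3ccc(Cl)cn3)c2)N=C(N)S1` has not yet been measured. It differs from compound 2 by hydrogen in place of fluoro on an aromatic carbon. For the measured compounds named here, no pair of measured compounds shows this change on its own, so the data give no direct guide to its size or direction. With nothing to suggest a larger shift, no change beyond the scatter is expected in this assay and the expected move is a number 2 percentage points lower from compound 2 to compound 3 (within the scatter) (a small estimated step). Compound 3 is estimated at 56% (expected range 40% to 72%).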

Compound 3, percent of the compound remaining: 13%
The estimate for compound 3 lay 43 percentage points above the measured number; measured number outside the range, below it.
By their numbers in this assay, from the lowest: compound 3; then compound 2; then compound 1.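

In this assay, hydrogen in place of fluoro on this aromatic carbon gives a number 45 percentage points lower from compound 2 to compound 3 (beyond the scatter). For the compounds shown here, this is the first step in the set that isolates a single change, and it shows that the read-out is highly sensitive to one atom at this place, ortho to a fluoro group, ortho to a large group and para to a ((5-chloropyridin-2-yl)carbonyl)amino group. Nothing measured here bears on why the number falls so far.

The compounds shown leave open whether the fluoro group is specifically needed here, or whether a chlorine atom, a methyl group or a methoxy group on the same carbon would give a similar number. They also leave open whether hydrogen in place of the remaining fluoro group of compound 3 would move the number further.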